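The source may report more compounds than this note shows. Statements on the series, on what has been measured and on what is new or still open speak of the compounds shown alone.

In a functional assay on K562 cells (Homo sapiens) for antiproliferative activity, read by CellTiter-Glo, with a stated time of 72 h (a lower number here means that less compound is needed, a higher number that more compound is needed for the effect), compound 3 `NS(=O)(=O)OC[C@H]1O[C@@H](n2cnc3c(NCc4cccs4)ncnc32)[C@H](O)[C@@H]1O` gives 114 nM and compound 1 `CCCCCCNc1ncnc2c1ncn2[C@@H]1O[C@H](COS(N)(=O)=O)[C@@H](O)[C@H]1O` gives 160 nM, and a 1.4-fold lower number from compound 1 to compound 3 (0.15 log units; within the scatter) keeps these two within the scatter of each other. Compound 2 `CCC(C)Nc1ncnc2c1ncn2[C@@H]1O[C@H](COS(N)(=O)=O)[C@@H](O)[C@H]1O` gives > 1000 nM, which is a limit. Compound 4 `NS(=O)(=O)OC[C@H]1O[C@@H](n2cnc3c(NC4CCCCCCC4)ncnc32)[C@H](O)[C@@H]1O` departs from compound 3 at one place: cyclooctyl in place of (thiophen-2-yl)methyl on a nitrogen on an aromatic ring. In words, cyclooctyl stands in place of (thiophen-2-yl)methyl on a nitrogen on an aromatic ring. Among the compounds with values here, no measured step makes this exact change, but three steps change the same group. Two involve the sec-butyl of compound 2, namely an at least 6.2-fold higher number from compound 1 to compound 2 (0.79 log units; beyond the scatter) and an at least 8.7-fold lower number from compound 2 to compound 3 (0.94 log units; beyond the scatter), and both are beyond the scatter. The third, a 1.4-fold lower number from compound 1 to compound 3 (0.15 log units; within the scatter), exchanges the two larger groups and stays within it. Cyclooctyl is larger than sec-butyl, so compound 4 is expected to sit nearer compound 1 and compound 3 than compound 2, though with some risk of a loss. The expected outcome is a 1.6-fold higher number from compound 3 to compound 4 (0.20 log units; within the scatter), a small rise and no clear step beyond the scatter. Compound 4 is estimated at 180 nM, with an expected range of 50 nM to 700 nM.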

Compound 4, half-maximal effective concentration: 380 nM
Beside the measured number, compound 4's estimate is 2.1-fold (0.32 log units) below it; the measured number falls inside the stated range.
By their numbers in this assay, from the lowest: compounds 3 and 1 (each within the scatter of the next); then compound 4. At a limit, above all of these: compound 2.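

In this assay, this position on a nitrogen on an aromatic ring now shows a measured cost for a non-aromatic ring of carbon only: a 3.3-fold higher number from compound 3 to compound 4 (0.52 log units; beyond the scatter) and a 2.4-fold higher number from compound 1 to compound 4 (0.38 log units; beyond the scatter), so cyclooctyl does not join the pair of (thiophen-2-yl)methyl and hexyl, which lie within the scatter of each other. Within the data shown here, it also stands apart from the branched group, with an at least 2.6-fold lower number from compound 2 to compound 4 (0.42 log units; beyond the scatter), which places compound 4 in a middle rank that the earlier compounds did not fill. That last step rests on a limit for compound 2: the limit of > 1000 nM in this assay, at which 1 of the 4 values shown sits.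

With only one saturated ring shown, ring size cannot be separated from the presence of a ring. On these data alone, whether cyclopentyl, cyclohexyl or benzyl would rank with compound 3 or with compound 4 stays open, as does the effect of a chain longer than hexyl.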